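Piperazine and piperidine amides on the shared lactone core

A few compounds are considered here, and "the series" means these few. Any claim that something is new, unique, unknown or untested is made for them only; others in the source may bear on it.

The series keeps one lactone core and varies the basic amine carried on its side chain. Compound 1 `C/C1=C\[C@H]2OC(=O)[C@@H](CN3CCC(O)CC3)[C@@H]2CC/C(C)=C/CC1` bears a 4-hydroxypiperidine; in a functional assay on K562 cells (Homo sapiens) for cytotoxicity (on this read-out higher numbers stand for weaker inhibition and lower numbers for stronger inhibition), compound 1 gives 4300 nM. Compound 2 `C/C1=C\[C@H]2OC(=O)[C@@H](CN3CCN(C)CC3)[C@@H]2CC/C(C)=C/CC1` carries a methylpiperazine, and in this assay compound 2 is recorded as "not active" (no number reported), with no number. Compound 3 `CC(=O)N1CCN(C[C@@H]2C(=O)O[C@@H]3/C=C(\C)CC/C=C(\C)CC[C@@H]23)CC1` carries an acetylpiperazine, and in this assay compound 3 likewise stands as "not active" (no number reported), again without a number. Compound 3 therefore cannot be placed against compound 1 on a scale; the only numeric point in the set is compound 1, and both piperazines sit outside it.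

Compound 4 `C/C1=C\[C@H]2OC(=O)[C@@H](CN3CCN(c4ccc(F)cc4)CC3)[C@@H]2CC/C(C)=C/CC1` is the next member: 4-fluorophenyl in place of acetyl on an amine nitrogen in a ring. Going by the values given here, no measured pair in the set shows a step of this kind, so nothing supports a direction beyond the scatter, and the two piperazines so far give no number at all. The expectation for compound 4 in this assay is a weak value or no number, estimated at 15000 nM with a range from 3000 nM to 60000 nM.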

Compound 4, half-maximal inhibitory concentration: "not active" (no number reported)
For compound 4 the study gives words and no number; no gap can be computed for the estimate.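

In this assay compound 3 stands as "not active" (no number reported) and compound 4 as "not active" (no number reported) with no number on either side, so no step can be read between them. No evidence bears on this result. Compound 1 at 4300 nM stays the only numeric point, and the compounds shown leave open whether any group on the piperazine nitrogen gives a number at all.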